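Swapping the aryl group on the acrylamide arm of compound 1

A few compounds are considered here, and "the series" means these few. Any claim that something is new, unique, unknown or untested is made for them only; others in the source may bear on it.

The three measured compounds share one core and differ at two ends. Compound 1 `COc1cc(/C=C/C(=O)Nc2cc3c(Nc4ccc(F)c(Cl)c4)ncnc3cc2OC)cc(OC)c1` gives 38500 nM in a functional assay on MCF7 cells (Homo sapiens) for cytotoxicity, read by MTT assay, with a stated time of 72 h; a lower number here means a stronger inhibitor, a higher number a weaker inhibitor. Compound 2 `COc1cc(/C=C/C(=O)Nc2cc3c(Nc4ccc(F)c(Cl)c4)ncnc3cc2O[C@H]2CCOC2)cc(OC)c1` gives 30300 nM, and the change a 1.3-fold lower number from compound 1 to compound 2 (0.10 log units; within the scatter) concerns only the ether group on the core. Compound 3 `O=C(/C=C/c1cc(Br)c(O)c(Br)c1)Nc1cc2c(Nc3ccc(F)c(Cl)c3)ncnc2cc1O[C@H]1CCOC1` gives 30600 nM, and the change a 1.0-fold higher number from compound 2 to compound 3 (0.00 log units; within the scatter) swaps the aryl group at the far end of the amide arm. Compound 1 carries the highest number of the three, but its gaps to compound 2 and compound 3 both fall within the usual scatter, so the three behave alike.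

Compound 4 `COc1cc2ncnc(Nc3ccc(F)c(Cl)c3)c2cc1NC(=O)/C=C/c1ccc(F)cc1Cl` is not yet measured. It differs from compound 1 in one place: 2-chloro-4-fluorophenyl in place of 3,5-dimethoxyphenyl on a double-bonded chain carbon bound to a double-bonded chain carbon. The step from compound 2 to compound 3 bears directly on this, since it alters the same aryl group at the same place, and it was a 1.0-fold higher number from compound 2 to compound 3 (0.00 log units; within the scatter), a step of no size beyond the scatter. The step from compound 1 to compound 2 touches a different place and is less informative.

Within the data shown here, with only one comparable step, and that one flat, no movement beyond the scatter is expected. Compound 4 is therefore estimated at 35000 nM in this assay, with a range from 15000 nM to 80000 nM, which corresponds to an expected step of a 1.1-fold lower number from compound 1 to compound 4 (0.04 log units; within the scatter).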

Compound 4, half-maximal inhibitory concentration: "not active" (no number reported)
Compound 4 has no reported number here; no gap can be computed for the estimate.
By their numbers in this assay, from the lowest: compounds 2, 3 and 1 (each within the scatter of the next).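

Compound 4 is reported as "not active" in this assay with no number, so the step from compound 1 to compound 4 cannot be read. The compounds shown leave open how far 2-chloro-4-fluorophenyl in place of 3,5-dimethoxyphenyl shifts the number. Nothing else given here helps explain this result.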